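The compounds below may be only part of what the source reports. "The series", "measured", "known", "first", "only" and "open" are said of these compounds alone.

Measured compounds:
Compound 1, `O=S(=O)(c1ccccc1)n1cc(-c2ccccc2)c2ccccc21`: in an assay on isolated protein for displacement of a labelled ligand from 5-hydroxytryptamine receptor 6 (Homo sapiens), read by scintillation counting, with a stated time of 1 h (a lower number here means a stronger inhibitor, a higher number a weaker inhibitor), compound 1 gives 146 nM.
Compound 2, `CN1CCN(c2ccc3c(ccn3S(=O)(=O)c3ccccc3)c2)CC1`: in this assay compound 2 gives 27 nM.

Of these two numbers, compound 2 holds the lower one. Its nearest neighbour is compound 1, whose number is higher by a margin that lies beyond the usual scatter of repeated measurements, so the two compounds are separated on the shown data. Compound 3, `O=S(=O)(c1ccccc1)n1ccc2cc(-c3ccncc3)ccc21`, has not yet been measured in this assay. It differs from compound 2 in one place: pyridin-4-yl in place of 4-methylpiperazin-1-yl on an aromatic carbon. Among the measured compounds shown here, no measured pair shows this kind of change, so the expected step rests only on the two numbers above and on the structural change itself. With the 4-methylpiperazin-1-yl group gone and pyridin-4-yl in its place, a moderate rise in the number is expected, a step that would go beyond the scatter but is not expected to carry compound 3 past the value of compound 1. The estimate for the step from compound 2 to compound 3 is a 3.0-fold higher number from compound 2 to compound 3 (0.47 log units; beyond the scatter). For compound 3 the expected value in this assay is 80 nM, with a range from 20 nM to 320 nM.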

Compound 3, inhibition constant: 409 nM
The estimate for compound 3 lay 5.1-fold (0.71 log units) below the measured number, and the stated range ends below it.
By their numbers in this assay, from the lowest: compound 2; then compound 1; then compound 3.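

The aromatic carbon that is meta to one fused ring and para to another proves sensitive to its substituent in this assay: pyridin-4-yl in place of 4-methylpiperazin-1-yl gives a 15-fold higher number from compound 2 to compound 3 (1.18 log units; beyond the scatter) and thus a large loss of strength at this site. The change is small in terms of size, since the group that leaves and the group that enters are both single six-membered rings, of 7 and 6 heavy atoms, so the number responds strongly to a swap that alters the ring type and the hetero atom count far more than the bulk. No measurement shown explains why the number rises so far.

Among the compounds shown here, the single pair cannot separate the effect of losing the non-aromatic ring from that of losing one of its nitrogens or its methyl group, and one step cannot establish a trend at this site. A piperazin-1-yl group without the methyl, or an open-chain amine such as dimethylamino, on the same carbon would be needed to tell which part of the 4-methylpiperazin-1-yl group carries the difference.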